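Swapping a carboxy group for (3-chlorophenyl)carbamoyl

The source may report more compounds than this note shows. Statements on the series, on what has been measured and on what is new or still open speak of the compounds shown alone.

Within the data shown here, compound 1 (`O=C(O)CCCCC(CCSC(=O)c1ccccc1)SC(=O)c1ccccc1`) gives 0.29% in a functional assay on HO8910 cells (Homo sapiens) for inhibition, read by MTT assay, with a stated time of 24 h, tested at 1 ug/mL (a lower number here means less inhibition of growth, a higher number more inhibition of growth at the concentration tested), and sits at the low end of the three numbers measured so far. Compound 2 (`COc1ccc(NC(=O)CCCCC(S)CCS)cc1`) gives 1.79% in the same test, which is within the usual scatter of compound 1, so these two cannot be told apart. Compound 3 (`CC(=O)SCCC(CCCCC(=O)Nc1ccccc1)SC(C)=O`) gives 10.6% here, and its gap to compound 1 lies beyond the scatter.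

Compound 4 (`O=C(CCCCC(CCSC(=O)c1ccccc1)SC(=O)c1ccccc1)Nc1cccc(Cl)c1`) has not yet been measured. It differs from compound 1 in one place, with (3-chlorophenyl)amino in place of hydroxy on a carbonyl carbon. Among the measured compounds shown here, no measured pair isolates this change, so the guidance is indirect. Compound 3 also has a nitrogen-linked group on that carbonyl carbon and gives 10.6%, which hints at a modest rise. Compound 2 shares that feature yet gives 1.79%, and so goes against the hint.

A small upward move in this assay is therefore expected, not clearly beyond the scatter, and the estimated step is a number 8.7 percentage points higher from compound 1 to compound 4 (within the scatter) in this test. For compound 4 the estimated value is 9%, with an expected range from 1% to 25% at this single concentration.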

Compound 4, percent growth inhibition at one concentration: 3.38%
Compound 4: middle estimate off by 5.6 percentage points, on the high side; the range from low to high includes it.
By their numbers in this assay, from the lowest: compounds 1, 2, 4 and 3 (each within the scatter of the next, the first and the last beyond it).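

In this assay, among these compounds, the step of a number 3.1 percentage points higher from compound 1 to compound 4 (within the scatter) gives the first direct reading of this position, since no earlier pair of compounds differed only on this carbonyl carbon. Even this sizeable change, which replaces a single hydroxy oxygen with (3-chlorophenyl)amino and brings in a six-membered aromatic ring, leaves compound 1 and compound 4 impossible to tell apart at the one concentration tested, so the position accepts the larger group without a readable gain or loss of growth inhibition in this test. Nothing available explains this result or shows how these compounds act on the cells.

The compounds shown leave open whether a different group on this carbonyl carbon, such as plain phenylamino without the chlorine, methoxy or a small amine such as dimethylamino, would give a clear step. As far as these compounds go, with both compounds near the bottom of the scale at one concentration, it also remains open whether a difference between them would appear at higher concentrations, where a full dose-response curve could separate them.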